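A few compounds are considered here, and "the series" means these few. Any claim that something is new, unique, unknown or untested is made for them only; others in the source may bear on it.

Working notes on the series. Compound 1, `c1ccc(-c2nc3sc(-c4ccccc4)cn3n2)cc1`, is the reference here. In a functional assay on A549 cells (Homo sapiens) for inhibition, read by sulforhodamine B assay, with a stated time of 48 h, tested at 10 uM (a lower number here means less inhibition of growth, a higher number more inhibition of growth at the concentration tested), compound 1 gives 10%, the lowest of the two values at hand. Compound 2, `COc1cc(-c2nc3sc(-c4ccccc4)cn3n2)cc(OC)c1OC`, gives 23% in this assay, a number that stands clearly above compound 1. Among the compounds with values here, no single-point step between these two is available. Compound 3, `Clc1ccc(-c2cn3nc(-c4ccccc4)nc3s2)cc1`, awaits measurement; it differs from compound 1 by chloro in place of hydrogen on an aromatic carbon. Within the data shown here, with no measured step of this kind, only a small change is expected in this assay, if any, leaning toward more inhibition: for compound 3 the expected step is a number 8 percentage points higher from compound 1 to compound 3 (within the scatter). The estimate for compound 3 in this assay is 18%, with a range from 5% to 32%.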

Compound 3, percent growth inhibition at one concentration: 36%
Compound 3: the middle estimate sits 18 percentage points below what was measured, and the stated range ends below it.
By their numbers in this assay, from the lowest: compound 1; then compound 2; then compound 3.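

Within the data shown here, the change from phenyl to 4-chlorophenyl gives the first single-point step: in this assay it reads a number 26 percentage points higher from compound 1 to compound 3 (beyond the scatter) at this position. This aromatic carbon, para to a large group, therefore responds to substitution, and one chlorine atom is enough to shift the read-out. Nothing at hand bears on the reason for this rise.

On these data alone, whether an amine or a carboxylic acid on this same carbon would shift the number in the same direction remains open. So does whether chloro on the other phenyl ring would have a comparable effect.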